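Replacing the dimethylphenyl with a methylthiophene

The compounds below may be only part of what the source reports. "The series", "measured", "known", "first", "only" and "open" are said of these compounds alone.

Compounds measured in a functional assay on DU-145 cells (Homo sapiens) for inhibition, read by trypan blue exclusion, with a stated time of 96 h (on this read-out higher numbers stand for weaker inhibition of growth and lower numbers for stronger inhibition of growth), so far
- compound 1 `COc1ccccc1/C=C(/SCc1ccc(F)cc1)C(=O)c1ccc(Br)cc1` gives 10000 nM here
- compound 2 `O=C(/C(=C\c1c[nH]c2ccc(Cl)cc12)SCc1ccc(F)cc1)c1ccc(Br)cc1` gives 1000 nM here
- compound 3 `Cc1ccc(C)c(/C=C(/SCc2ccc(F)cc2)C(=O)c2ccc(Br)cc2)c1` gives 1000 nM here

Compound 3 stands level with compound 2, and together they hold the lowest of the three numbers. Within the data shown here, the next structure is compound 4 `Cc1ccsc1/C=C(/SCc1ccc(F)cc1)C(=O)c1ccc(Br)cc1`, which carries 3-methylthiophen-2-yl in place of 2,5-dimethylphenyl on a double-bonded chain carbon bound to a double-bonded chain carbon as its only change.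

All three measured steps concern this same place. Both a 10-fold lower number from compound 1 to compound 2 (1.00 log units; beyond the scatter) and a 10-fold lower number from compound 1 to compound 3 (1.00 log units; beyond the scatter) are modest, while no change at the digits printed from compound 2 to compound 3 (within the scatter) lies within the scatter. That last step supports expecting no step beyond the scatter in this assay for this change. Among the measured compounds shown here, no measured compound carries the 3-methylthiophen-2-yl group, so the range is kept wide. The expected change is a 1.5-fold higher number from compound 3 to compound 4 (0.18 log units; within the scatter) and would stay within the scatter. For compound 4 the estimated value is 1500 nM, with an expected range from 400 nM to 6000 nM in this measurement.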

Compound 4, concentration for 50% growth inhibition: 50000 nM
Compound 4: middle estimate off by 33-fold (1.52 log units), on the low side; the measured number lies above the stated range.
By their numbers in this assay, from the lowest: compounds 2 and 3 (each within the scatter of the next); then compound 1; then compound 4.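

In this assay, among these compounds, this position proves far less forgiving than the earlier compounds suggested: 3-methylthiophen-2-yl in place of 2,5-dimethylphenyl gives a 50-fold higher number from compound 3 to compound 4 (1.70 log units; beyond the scatter), and in place of 5-chloro-1H-indol-3-yl it gives a 50-fold higher number from compound 2 to compound 4 (1.70 log units; beyond the scatter). The new group also falls behind 2-methoxyphenyl, until now the group with the highest number, with a 5.0-fold higher number from compound 1 to compound 4 (0.70 log units; beyond the scatter). The earlier parity of the indolyl and dimethylphenyl groups therefore does not extend to every aromatic ring at this place, and compound 4 is the weakest of the four on this read-out.

Nothing available here accounts for the size of this loss. The compounds shown leave open whether it follows the sulfur, the five-membered ring or the methyl group, which a thiophen-2-yl without the methyl, or a pyridinyl group, could help separate.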